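Notes on two benzisoxazole acids and a proposed amide

The source may report more compounds than this note shows. Statements on the series, on what has been measured and on what is new or still open speak of the compounds shown alone.

Measured compounds:
Compound 1, `O=C(O)/C=C/c1ccc2noc(-c3ccc(Oc4ccccc4)cc3)c2c1`: 94 nM
Compound 2, `O=C(O)c1ccc2noc(-c3ccc(Oc4ccccc4)cc3)c2c1`: 280 nM

In an assay for inhibition of inositol hexakisphosphate kinase 2 (Homo sapiens), read by colorimetric assay, coupled enzyme assay and malachite green, with a stated time of 120 min, in the presence of a further agent that is not named here (a higher number here means a weaker inhibitor, a lower number a stronger inhibitor), compound 2 gives 280 nM, the highest of the two numbers measured. For the measured compounds named here, its nearest neighbour is compound 1, and the one step measured, a 3.0-fold higher number from compound 1 to compound 2 (0.47 log units; beyond the scatter), is the only change known; it concerns the acid-bearing side of the core.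

Compound 3, `O=C(O)c1ccc2noc(-c3ccc(NC(=O)C4CCCC4)cc3)c2c1`, is not yet measured. It differs from compound 2 as follows: (cyclopentylcarbonyl)amino in place of phenoxy on an aromatic carbon. Going by the values given here, the change sits on the opposite side of the core from the acid, and no measured step touches that side. The step from compound 1 to compound 2 therefore does not bear on the change from compound 2 to compound 3; it only shows that the acid side, held constant here, tolerates some variation with a modest change in number.

Among the compounds with values here, with no comparable step in hand, the number for compound 3 is expected to stay near that of compound 2, the estimated step being a 1.1-fold higher number from compound 2 to compound 3 (0.03 log units; within the scatter), with a wide range. The estimate for compound 3 is 300 nM, between 80 nM and 1200 nM.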

Compound 3, half-maximal inhibitory concentration: 190 nM
The estimate for compound 3 lay 1.6-fold (0.20 log units) above the measured number; measured number inside the range.
By their numbers in this assay, from the lowest: compound 1; then compounds 3 and 2 (each within the scatter of the next).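

In this assay, for the compounds shown here, the first measured change at this position, on an aromatic carbon para to a large group, replaces phenoxy with (cyclopentylcarbonyl)amino and gives a 1.5-fold lower number from compound 2 to compound 3 (0.17 log units; within the scatter). The position therefore keeps its number through an exchange in which a six-membered aromatic ring gives way to a five-membered non-aromatic ring and a hydrogen-bond donor enters, which the acid-side step, a 3.0-fold higher number from compound 1 to compound 2 (0.47 log units; beyond the scatter), could not show. Nothing measured here accounts for this result.

The compounds shown do not separate the contribution of the amide hydrogen from that of the cyclopentyl ring, so an N-methyl amide, an acetylamino group or a cyclohexyl ring in place of cyclopentyl would be needed to tell these apart. Going by these compounds, it also remains open whether the 2-carboxyethenyl group of compound 1, at 94 nM, would keep its step from the carboxy group when paired with (cyclopentylcarbonyl)amino rather than phenoxy.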